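Compound 3 and the loss of the (piperidin-1-yl)methyl group

The source may report more compounds than this note shows. Statements on the series, on what has been measured and on what is new or still open speak of the compounds shown alone.

In a physicochemical assay for solubility, read by chemiluminescence, in phosphate buffer, measured as kinetic solubility, at pH 7.4 (on this read-out higher numbers stand for higher solubility and lower numbers for lower solubility), compound 1 `Cn1ccc(Nc2ccc(C(=O)NCC3(c4nc(-c5ccccc5)cs4)CCOCC3)cc2)n1` gives 48000 nM. Compound 2 `O=C(NCC1(c2nc(-c3ccccc3)cs2)CCOCC1)c1ccc(CN2CCCCC2)cc1` reads >= 396000 nM, which is a limit of the assay and not a number. Compound 3 `Cn1c(Nc2ccc(C(=O)NCC3(c4nc(-c5ccccc5)cs4)CCOCC3)cc2)nc2ccccc21` carries (1-methyl-1H-benzimidazol-2-yl)amino in place of (piperidin-1-yl)methyl on an aromatic carbon. Going by the values given here, only one measured step bears on this, an at least 8.2-fold higher number from compound 1 to compound 2 (0.91 log units; beyond the scatter), which brought in the same (piperidin-1-yl)methyl group, so a fall of at least that size is expected in this assay here. The expected step is an at least 15-fold lower number from compound 2 to compound 3 (1.19 log units; beyond the scatter). For compound 3 the estimate is 25000 nM, with an expected range of 5000 nM to 90000 nM.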

Compound 3, solubility: 10000 nM
Compound 3: the middle estimate sits 2.5-fold (0.40 log units) above what was measured, and the stated range covers the measured number.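

Putting (1-methyl-1H-benzimidazol-2-yl)amino in place of (piperidin-1-yl)methyl on this aromatic carbon gives an at least 39-fold lower number from compound 2 to compound 3 (1.59 log units; beyond the scatter) in this assay. The group on the linking nitrogen matters as well, since 1-methyl-1H-benzimidazol-2-yl in place of 1-methyl-1H-pyrazol-3-yl gives a 4.8-fold lower number from compound 1 to compound 3 (0.68 log units; beyond the scatter), so two different amino-linked groups at this position read differently. The reading for compound 2 is a limit of the assay, not a number: the limit of >= 396000 nM in this assay, at which 1 of the 3 values shown sits.

As far as these compounds go, the true size of the fall from compound 2 therefore stays open. So does how a morpholine, a dimethylamino group or a carboxylic acid would read at this position.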